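Swapping the Aryl Group on the Carbonyl

The source may hold more compounds than are shown below. What is called first, only, known or untested is meant among the compounds shown, and "the series" means these compounds.

Two related compounds have been tested in a functional assay on MDA-MB-435 cells (Homo sapiens) for inhibition, read by sulforhodamine B assay, with a stated time of 48 h; a higher number here means a weaker inhibitor of growth, a lower number a stronger inhibitor of growth. Compound 1 `COc1ccc(-c2cc(/C=C/C(=O)c3ccc(N)cc3)[nH]n2)cc1` gives 7000 nM in this assay. Compound 2 `COc1cc(-c2cc(/C=C/C(=O)c3ccc(Cl)c(Cl)c3)[nH]n2)cc(OC)c1OC` reaches only a limit of the assay in this assay, reported as > 100000 nM, and its true value is not known beyond that (the limit of > 100000 nM in this assay, at which 1 of the 2 values shown sits). Compound 3 `COc1ccc(C(=O)/C=C/c2cc(-c3cc(OC)c(OC)c(OC)c3)n[nH]2)cc1` differs from compound 2 in one place: 4-methoxyphenyl in place of 3,4-dichlorophenyl on a carbonyl carbon. Within the data shown here, no measured pair shows what this change does, so only the weak result of compound 2 guides the expectation. Compound 3 is expected to give about 50000 nM in this assay, within 10000 nM to 150000 nM. The expected step of an at least 2.0-fold lower number from compound 2 to compound 3 (0.30 log units; that floor lies within the scatter) is therefore modest and uncertain.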

Compound 3, concentration for total growth inhibition: 5690 nM
For compound 3 the middle estimate is 8.8-fold (0.94 log units) above the measured one; the measured number lies below the stated range.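

In this assay, the group on this carbonyl carbon has a large effect: 4-methoxyphenyl in place of 3,4-dichlorophenyl gives an at least 17-fold lower number from compound 2 to compound 3 (1.24 log units; beyond the scatter). Compound 2 stands at > 100000 nM, which is a limit of the assay and not a number, and the true step may be larger still. With the rest of the molecule unchanged, this one position separates a readable value from a result at the limit.

The two compounds cannot show whether the step comes from gaining the methoxy group or from losing the two chlorines. Going by these compounds, what a plain phenyl or a 4-hydroxyphenyl would give at this carbonyl carbon also stays open.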